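The source may hold more compounds than are shown below. What is called first, only, known or untested is meant among the compounds shown, and "the series" means these compounds.

Measured so far in a functional assay on MCF7 cells (Homo sapiens) for inhibition, read by MTT assay, with a stated time of 72 h; a higher number here means a weaker inhibitor, a lower number a stronger inhibitor:

- compound 1 `CN(C(=O)NC(=O)c1ccccc1F)c1nc(C(F)(F)F)c(C(=O)N/N=C/c2ccc(C(F)(F)F)cc2)s1` gives 4.98 ug/mL
- compound 2 `CN(C(=O)NC(=O)c1ccc(F)c(F)c1)c1nc(C(F)(F)F)c(C(=O)N/N=C/c2ccc(C(F)(F)F)cc2)s1` gives 5.93 ug/mL
- compound 3 `CN(C(=O)NC(=O)c1c(F)cccc1F)c1nc(C(F)(F)F)c(C(=O)N/N=C/c2ccc(C(F)(F)F)cc2)s1` gives 35.3 ug/mL

Compound 1 has the lowest number of the three, but the step of a 1.2-fold higher number from compound 1 to compound 2 (0.08 log units; within the scatter) is within the scatter, so compounds 1 and 2 cannot be ordered. The steps of a 7.1-fold higher number from compound 1 to compound 3 (0.85 log units; beyond the scatter) and a 6.0-fold higher number from compound 2 to compound 3 (0.77 log units; beyond the scatter) are both beyond the scatter; each concerns only the fluorine pattern of the fluorophenyl on a carbonyl carbon, with the rest of the shared core unchanged.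

Compound 4 `CNc1nc(C(F)(F)F)c(C(=O)N/N=C/c2ccc(C(F)(F)F)cc2)s1` differs from compound 1 by hydrogen in place of ((2-fluorophenyl)carbonyl)carbamoyl on a nitrogen on an aromatic ring. Within the data shown here, none of the measured steps touches this part of the structure: all three measured compounds keep a ((fluorophenyl)carbonyl)carbamoyl on that nitrogen and differ only within it. Among the measured compounds shown here, no measured step therefore bears on the step from compound 1 to compound 4, and the expectation rests on the spread of the series alone. Given that spread, a step beyond the scatter, towards a higher number, is the expected outcome, with a wide range: a 3.0-fold higher number from compound 1 to compound 4 (0.48 log units; beyond the scatter). Compound 4 is accordingly estimated at 15 ug/mL in this assay, within 3 ug/mL to 70 ug/mL.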

Compound 4, half-maximal inhibitory concentration: > 100 ug/mL
Compound 4: no number, only a limit; the forecaster's own chance of this, stated with the estimate: 15%; middle value at least 6.6-fold (0.82 log units) from the limit.
By their numbers in this assay, from the lowest: compounds 1 and 2 (each within the scatter of the next); then compound 3. At a limit, above all of these: compound 4.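

In this assay compound 4 gives > 100 ug/mL, which is a limit of the assay and not a number: the limit of > 100 ug/mL in this assay, at which 1 of the 4 values shown sits.

Among these compounds, the step of an at least 20-fold higher number from compound 1 to compound 4 (1.30 log units; beyond the scatter) is the first reading at this position, the nitrogen on an aromatic ring, and it replaces the whole ((2-fluorophenyl)carbonyl)carbamoyl with hydrogen. The earlier compounds shown here showed only that the fluorine pattern within this group can move the number, as in the step of a 7.1-fold higher number from compound 1 to compound 3 (0.85 log units; beyond the scatter). Among the four compounds shown, the three that carry a ((fluorophenyl)carbonyl)carbamoyl on this nitrogen all give measured numbers, while compound 4, the only one with hydrogen there, gives only a limit.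

As far as these compounds go, what remains open is which part of the group goes with the measured numbers, the fluorophenyl or the carbonyl and carbamoyl portion: an acetyl, a methylcarbamoyl or a benzoyl on the same nitrogen would begin to separate these parts. Also open, from the compounds shown here alone, is whether an unsubstituted phenyl or a chloro in place of fluoro on the phenyl would keep compound 1's level in this assay.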